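Trioxane carboxylic acids: epimer at the ring stereocentre

The compounds below may be only part of what the source reports. "The series", "measured", "known", "first", "only" and "open" are said of these compounds alone.

Measured so far:
compound 1 `C=C1CCCC(C)(C)C1CC[C@]1(C)CC[C@H]([C@@H](C)C(=O)OC)OO1` — 3190 nM
compound 2 `CC1=C(CC/C(C)=C/CC[C@@]2(C)CC[C@@H]([C@H](C)C(=O)O)OO2)C(C)(C)CCC1` — > 100000 nM

Two compounds carry numbers in a functional assay on SF-268 cells (Homo sapiens) for inhibition; a higher number here means a weaker inhibitor of growth, a lower number a stronger inhibitor of growth. Compound 1 `C=C1CCCC(C)(C)C1CC[C@]1(C)CC[C@H]([C@@H](C)C(=O)OC)OO1` gives 3190 nM in this assay. Compound 2 `CC1=C(CC/C(C)=C/CC[C@@]2(C)CC[C@@H]([C@H](C)C(=O)O)OO2)C(C)(C)CCC1` reaches only the limit of this assay, > 100000 nM, and no number within range; it therefore sits at the weaker end of what has been recorded, as the evidence shows: the limit of > 100000 nM in this assay, at which 1 of the 2 values shown sits. No single-point change between measured compounds is available, so nothing about the size of a stereochemical step is known from measurements here.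

Compound 3 `CC1=C(CC/C(C)=C/CC[C@@]2(C)CC[C@H]([C@H](C)C(=O)O)OO2)C(C)(C)CCC1` is the next candidate. Its difference from compound 2 is the two compounds have the same atoms and bonds and differ only in configuration as drawn: 1 of 4 stereo elements differ; a stereocentre at a saturated ring carbon is drawn S in compound 2 and R in compound 3. A change in configuration at one ring stereocentre can move growth inhibition in either direction; with compound 2 at the limit, the expectation for this assay is a step within the scatter, or at most a modest gain, with a real chance that the result is again only a limit. Compound 3 is expected to give about 90000 nM in this assay, within 10000 nM to 500000 nM. This estimate means a step of an at least 1.1-fold lower number from compound 2 to compound 3 (0.04 log units; that floor lies within the scatter), a change expected to be small.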

Compound 3, concentration for 50% growth inhibition: > 5000 nM
Compound 3 gave a limit, no number (the forecaster's own chance of this, stated with the estimate: 55%); the middle value is on the limit's open side.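

In this assay compound 2 and compound 3 each give only a limit and no number, and no step can be read between them. On these data alone, whether the configuration at the saturated ring carbon, the only difference between these two compounds, changes growth inhibition at all, and in which direction, remains open.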